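The source may report more compounds than this note shows. Statements on the series, on what has been measured and on what is new or still open speak of the compounds shown alone.

Measured so far in an assay on microsomes from brain for inhibition of Fatty-acid amide hydrolase 1 (Rattus norvegicus), read by fluorescence and HPLC, with a stated time of 60 min; on this read-out higher numbers stand for weaker inhibition and lower numbers for stronger inhibition:
compound 1 `CCCCCCCCc1ccc(OCC(=O)Cn2nnnc2C)cc1`, for which compound 1 gives 41 nM
compound 2 `CCCCCCCCc1ccc(OCC(=O)Cn2nnnc2SC)cc1`, for which compound 2 gives 22 nM
compound 3 `CCCCCCCCc1ccc(OCC(=O)Cn2nnnc2-c2ccncc2)cc1`, for which compound 3 gives 190 nM

Compound 3 stands at the highest number of the three. Its two steps from the smaller substituents are both beyond the scatter: a 4.6-fold higher number from compound 1 to compound 3 (0.67 log units; beyond the scatter) and an 8.6-fold higher number from compound 2 to compound 3 (0.94 log units; beyond the scatter). The remaining step, a 1.9-fold lower number from compound 1 to compound 2 (0.27 log units; within the scatter), is within the scatter, so the methyl and methylsulfanyl compounds are not told apart here.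

Compound 4 `CCCCCCCCc1ccc(OCC(=O)Cn2nnnc2-c2ccccn2)cc1` differs from compound 3 by one change: pyridin-2-yl in place of pyridin-4-yl on an aromatic carbon. Going by the values given here, no measured step changes the attachment point of a pyridyl ring; the two steps that reach compound 3 only show that a pyridin-4-yl at this carbon yields a higher number than methyl or methylsulfanyl. Nothing in the series says whether pyridin-2-yl behaves like pyridin-4-yl or like the smaller groups. The expected outcome is therefore no step beyond the scatter, with the estimate a 1.1-fold lower number from compound 3 to compound 4 (0.02 log units; within the scatter), the range widened to allow a partial return toward compound 1. Compound 4 is estimated at 180 nM in this assay, expected to fall between 60 nM and 550 nM.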

Compound 4, half-maximal inhibitory concentration: 880 nM
Beside the measured number, compound 4's estimate is 4.9-fold (0.69 log units) below it; measured number outside the range, above it.
By their numbers in this assay, from the lowest: compounds 2 and 1 (each within the scatter of the next); then compound 3; then compound 4.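

In this assay the attachment point of the pyridyl ring on this aromatic carbon counts by itself: with the same atoms joined differently, the series gives a 4.6-fold higher number from compound 3 to compound 4 (0.67 log units; beyond the scatter) and so tells the two pyridyl compounds apart. Against the smaller groups, pyridin-2-yl opens a wider gap than pyridin-4-yl did, with a 21-fold higher number from compound 1 to compound 4 (1.33 log units; beyond the scatter) and a 40-fold higher number from compound 2 to compound 4 (1.60 log units; beyond the scatter) among these four compounds, so the cost of a pyridyl ring at this carbon is not fixed but depends on how the ring is attached. No measurement at hand accounts for the difference between the two attachment points.

Still open, going by these compounds, is where pyridin-3-yl would fall at this carbon, and whether a plain phenyl ring, with no ring nitrogen, would stand nearer compound 3 or compound 4. Also open, on these data alone, is whether the order of the two pyridyl compounds would hold with a shorter chain in place of the octyl chain on the shared core.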